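Swapping Isopropyl for Cyclopropylmethyl on a Shared Core

This account rests on a few compounds, and the source may have more. Where it says the series, first, only, none or still open, it means among the compounds named here.

Compound 1 `CC(C)c1cnc(Nc2cccc(F)c2)nc1NCCCNC(=O)C1CCC1`: > 1000 nM
Compound 2 `Cn1ccc(Nc2ncc(C3CC3)c(NCCCNC(=O)C3CCC3)n2)n1`: > 1000 nM

Of the compounds shown here, two have been measured in an assay on isolated protein for inhibition of serine/threonine-protein kinase TBK1 (Homo sapiens); on this read-out lower numbers stand for stronger inhibition and higher numbers for weaker inhibition. For compound 1 the value > 1000 nM is a limit of the assay rather than a number. For compound 2 the value > 1000 nM is likewise a limit. Compound 1 thus stands at the edge of what can be reported here, and this holds across everything measured: the limit of > 1000 nM in this assay, at which 2 of the 2 values shown sit. Neither compound gives a measurable figure.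

Compound 3 `O=C(NCCCNc1nc(Nc2cccc(F)c2)ncc1CC1CC1)C1CCC1` has not been measured. It differs from compound 1 in one place: cyclopropylmethyl in place of isopropyl on an aromatic carbon. Going by the values given here, with no measured step to lean on and both known values being limits, the expected change in this assay from compound 1 to compound 3 is none beyond the scatter. Compound 3 is therefore expected to give about 3000 nM, plausibly between 800 nM and 20000 nM. The step that the limit leaves unreadable from compound 1 to compound 3 is estimated to be small.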

Compound 3, half-maximal inhibitory concentration: > 1000 nM
Compound 3: only a limit was reported (the forecaster's own chance of this, stated with the estimate: 75%); the middle value does not contradict the limit.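

Compound 3 gives > 1000 nM as a limit of the assay, not a number. Going by these compounds alone, no step from compound 1 to compound 3 can be read, because every value shown sits at the same limit: the limit of > 1000 nM in this assay, at which 3 of the 3 values shown sit. The compounds shown leave open how strongly each one actually inhibits the kinase, and whether cyclopropylmethyl or isopropyl on the shared core gives stronger inhibition.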